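This account rests on a few compounds, and the source may have more. Where it says the series, first, only, none or still open, it means among the compounds named here.

Compound 1 `Oc1ccc(-c2ccc(-c3ccc(-c4nc5ccccc5[nH]4)cc3)cc2)cc1` carries a hydroxy group on the shared core, and in a functional assay on MCF7 cells (Homo sapiens) for inhibition, read by sulforhodamine B assay (on this read-out higher numbers stand for weaker inhibition of growth and lower numbers for stronger inhibition of growth), compound 1 gives 30500 nM. Compound 2 `COc1ccc(-c2ccc(-c3ccc(-c4nc5ccccc5[nH]4)cc3)cc2)cc1` differs from it only in methyl in place of hydrogen on an oxygen on an aromatic ring; in this assay compound 2 gives 33300 nM, and the step of a 1.1-fold higher number from compound 1 to compound 2 (0.04 log units; within the scatter). Compound 3 `Oc1ccc(-c2ccc(-c3ccc(-c4nc5c(O)cccc5[nH]4)cc3)cc2)cc1` differs from compound 1 in a different place, namely (hydroxy in place of hydrogen on an aromatic carbon); in this assay compound 3 gives 190 nM, and the step of a 160-fold lower number from compound 1 to compound 3 (2.21 log units; beyond the scatter). So far this is the only large step seen, and no other compound speaks against it. Among the measured compounds shown here, compound 4 `COc1ccc(-c2ccc(-c3ccc(-c4nc5c(O)cccc5[nH]4)cc3)cc2)cc1` has not yet been measured; it differs from compound 3 by methyl in place of hydrogen on an oxygen on an aromatic ring, which is the same change as the one that turns compound 1 into compound 2, made on the same kind of oxygen. Because that earlier change gave a 1.1-fold higher number from compound 1 to compound 2 (0.04 log units; within the scatter), the expected step here is small, a 1.2-fold higher number from compound 3 to compound 4 (0.08 log units; within the scatter). Compound 4 is therefore estimated to give 230 nM, with the likely range running from 90 nM to 600 nM.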

Compound 4, concentration for 50% growth inhibition: 3110 nM
Compound 4: the middle estimate sits 14-fold (1.13 log units) below what was measured; the whole stated range lies below it.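

In this assay, methyl in place of hydrogen on the oxygen matters far more once the second hydroxy is present, where the step is a 16-fold higher number from compound 3 to compound 4 (1.21 log units; beyond the scatter), so this change cannot be carried unaltered from one core to the other: the same change on two cores in this assay, a 1.1-fold higher number (0.04 log units; within the scatter) from compound 1 to compound 2 and a 16-fold higher number (1.21 log units; beyond the scatter) from compound 3 to compound 4, 15-fold (1.18 log units) apart, beyond the scatter of two such steps. Seen the other way, hydroxy in place of hydrogen on an aromatic carbon still gives a large gain on the methoxy core, with the step being an 11-fold lower number from compound 2 to compound 4 (1.03 log units; beyond the scatter), yet that gain is smaller than on the hydroxy core: the same change on two cores in this assay, a 160-fold lower number (2.21 log units; beyond the scatter) from compound 1 to compound 3 and an 11-fold lower number (1.03 log units; beyond the scatter) from compound 2 to compound 4, 15-fold (1.18 log units) apart, beyond the scatter of two such steps. The two changes therefore do not simply add up in these compounds, but four compounds cannot show why, or whether the same holds on any other core.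

Going by these compounds, it remains open whether an ethyl group on that same oxygen would behave like the methyl group. On these data alone, it also remains open whether an amine in place of the added hydroxy would give a similar gain.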